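Halophenyl amide variation at the anilide end of the series

The source may hold more compounds than are shown below. What is called first, only, known or untested is meant among the compounds shown, and "the series" means these compounds.

Working notes on three anilides sharing one core. Compound 1 `CC(C)COc1ccc(NC(=O)CCCCCCCSc2nnc(Cc3nn(C)c(=O)c4ccccc34)n2C)cc1` carries an eight-carbon linker and in an assay on isolated protein (Mus musculus) for inhibition of IL15-IL15 receptor (Homo sapiens), read by resazurin assay, with stated times of 30 min and 2.5 days (a higher number here means a weaker inhibitor, a lower number a stronger inhibitor), compound 1 gives 4800 nM. Compound 2 `CC(C)Oc1ccc(NC(=O)CSc2nnc(Cc3nn(C)c(=O)c4ccccc34)n2C)cc1` has the short linker and a 4-isopropoxyphenyl amide. For compound 2 the result in this assay is a limit, > 30000 nM; note (the limit of > 30000 nM in this assay, at which 1 of the 3 values shown sits). Compound 3 `Cn1c(Cc2nn(C)c(=O)c3ccccc23)nnc1SCC(=O)Nc1ccc(Cl)cc1Cl` keeps the short linker with a 2,4-dichlorophenyl amide, and in this assay compound 3 gives 17300 nM, the highest of the two numbers recorded, compound 1 lower. Among the compounds with values here, the step of an at least 1.7-fold lower number from compound 2 to compound 3 (0.23 log units; that floor lies within the scatter) is the only measured change at the amide nitrogen. Compound 4 `Cn1c(Cc2nn(C)c(=O)c3ccccc23)nnc1SCC(=O)Nc1ccc(I)cc1` differs from compound 3 by 4-iodophenyl in place of 2,4-dichlorophenyl on an amide-type nitrogen. Within the data shown here, only the step from compound 2 to compound 3 bears on this, and its floor lies within the scatter, so no step beyond the scatter in this assay is expected. The estimate for compound 4 is therefore 20000 nM, range 8000 nM to 50000 nM, meaning an expected step of a 1.2-fold higher number from compound 3 to compound 4 (0.06 log units; within the scatter).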

Compound 4, half-maximal inhibitory concentration: "not active" (no number reported)
No number was reported for compound 4; no gap can be computed for the estimate.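

In this assay, within the data shown here, compound 4 is recorded as "not active" with no number, and no step between compound 3 and compound 4 can be read. The compounds shown leave open whether compound 4 falls with compound 2, whose result is a limit: the limit of > 30000 nM in this assay, at which 1 of the 4 values shown sits.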